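A few compounds are considered here, and "the series" means these few. Any claim that something is new, unique, unknown or untested is made for them only; others in the source may bear on it.

Compound 1, `N=C1S/C(=C\c2ccc(OCc3ccccc3)cc2)C(=O)N1c1ccccc1[N+](=O)[O-]`, in an ADME assay on RAW264.7 cells (Mus musculus) for cytotoxicity, read by MTT assay, with a stated time of 48 h, tested at 50 uM; a higher number here means more inhibition at the concentration tested (going by the name of the read-out), a lower number less inhibition: 24.4%
Compound 2, `Cc1cccc(N2C(=N)S/C(=C\c3ccc(OCc4ccccc4)cc3)C2=O)n1`, in this assay : 25.1%

Within the data shown here, on the numbers so far, compound 2 and compound 1 sit within the scatter of each other, the step of a number 0.7 percentage points higher from compound 1 to compound 2 (within the scatter) being too small to separate them. Compound 3, `Cc1ccc(C)c(N2C(=N)S/C(=C\c3ccc(OCc4ccccc4)cc3)C2=O)c1`, differs from compound 2 by 2,5-dimethylphenyl in place of 6-methylpyridin-2-yl on an amide-type nitrogen in a ring. Among the measured compounds shown here, the only measured step bearing on this, a number 0.7 percentage points higher from compound 1 to compound 2 (within the scatter), also exchanged the aromatic group on that ring nitrogen and changed the read-out by nothing beyond the scatter, so no step beyond the scatter is expected here either. For compound 3 the expected step is a number 0.1 percentage points lower from compound 2 to compound 3 (within the scatter). Compound 3 is estimated at 25%, with a range from 12% to 38%.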

Compound 3, a percentage reported as inhibition, at one concentration (the size of the read-out at that concentration, not a potency): 45.8%
Compound 3: middle estimate off by 20.8 percentage points, on the low side, and the stated range ends below it.
By their numbers in this assay, from the lowest: compounds 1 and 2 (each within the scatter of the next); then compound 3.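

The aromatic group on this amide-type nitrogen in a ring can matter after all in this assay. With 2,5-dimethylphenyl there, the read-out shows a number 20.7 percentage points higher from compound 2 to compound 3 (beyond the scatter), and likewise a number 21.4 percentage points higher from compound 1 to compound 3 (beyond the scatter), although the exchange between the other two groups moved nothing beyond the scatter. Nothing available here explains this rise.

From the compounds shown here alone, whether it follows the carbon-only ring or the methyl groups stays open. So does how an aminophenyl or carboxyphenyl group at this place would read.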